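Cyclopropane aryl swap on the free-amine analogue

A few compounds are considered here, and "the series" means these few. Any claim that something is new, unique, unknown or untested is made for them only; others in the source may bear on it.

Three compounds of the series carry the shared core with a 2-arylcyclopropane amide. Compound 1 `CC[C@H](C)[C@@H](CN(C(=O)[C@@H]1C[C@H]1c1ccccc1)c1ccc(-c2ccccc2)cc1)NC(C)=O` gives 5.8 nM in a functional assay for agonist activity at G protein-coupled receptor 88 (Homo sapiens), read by HTRF and cAMP accumulation; a higher number here means that more compound is needed for the effect, a lower number that less compound is needed. For the measured compounds named here, compound 2 `O=C([C@@H]1C[C@H]1c1ccccc1)N(CCNCC1CCCC1)c1ccc(-c2ccccc2)cc1` gives 2.5 nM; the only one-place step measured is a 2.3-fold lower number from compound 1 to compound 2 (0.37 log units; beyond the scatter). Compound 3 `CC[C@H](C)[C@H](N)CN(C(=O)[C@@H]1C[C@H]1c1ccc(F)cc1)c1ccc(-c2ccccc2)cc1`, which carries a free amine and a 4-fluorophenyl on the cyclopropane, gives 600 nM, the highest number of the three and well beyond the scatter from both compound 1 and compound 2.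

Compound 4 `CC[C@H](C)[C@H](N)CN(C(=O)[C@@H]1C[C@H]1c1csc(C)n1)c1ccc(-c2ccccc2)cc1` differs from compound 3 in one place: 2-methyl-1,3-thiazol-4-yl in place of 4-fluorophenyl on a saturated ring carbon. Going by the values given here, no measured step touches the aryl group on the cyclopropane; the single step measured, from compound 1 to compound 2, concerns the side chain on the amide nitrogen and says nothing about this position. There is therefore no basis for expecting a step beyond the scatter in either direction, and the uncertainty is wide.

The estimate for compound 4 is 600 nM, with a range from 150 nM to 2400 nM, which corresponds to an expected step of no change at the digits printed from compound 3 to compound 4 (within the scatter).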

Compound 4, half-maximal effective concentration: 1500 nM
Compound 4: middle estimate off by 2.5-fold (0.40 log units), on the low side; low and high end bracket the measured number.
By their numbers in this assay, from the lowest: compound 2; then compound 1; then compound 3; then compound 4.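

In this assay, the aryl group on the cyclopropane now has a measured step of its own: 2-methyl-1,3-thiazol-4-yl in place of 4-fluorophenyl gives a 2.5-fold higher number from compound 3 to compound 4 (0.40 log units; beyond the scatter). The position therefore responds to this exchange of a six-membered aromatic ring of carbon only for a five-membered aromatic ring with 2 hetero atoms, although the step is modest and is read only on the free-amine side chain shared by compound 3 and compound 4. No measurement at hand accounts for the step, so its cause stays unassigned.

From the compounds shown here alone, it remains open whether the step comes from the ring itself or from its methyl group; an unmethylated 1,3-thiazol-4-yl would separate the two, and pyridin-3-yl or 4-chlorophenyl would extend the comparison to other six-membered rings. Going by these compounds, it is also open whether the same exchange gives a step of similar size and direction with the acetamido side chain of compound 1 or the cyclopentylmethylamino side chain of compound 2.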